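A Halophenyl Exchange at the Amine Nitrogen

This account rests on a few compounds, and the source may have more. Where it says the series, first, only, none or still open, it means among the compounds named here.

Of the compounds shown here, two sharing one core have been measured in a functional assay on MCF7 cells (Homo sapiens) for inhibition, read by sulforhodamine B assay; on this read-out higher numbers stand for weaker inhibition and lower numbers for stronger inhibition. Compound 1 `COc1ccc(NC2=CC(=O)c3c(nc4n3[C@H]3OC[C@@H](O)[C@H]3OC4)C2=O)cc1` gives 4470 nM in this assay. Compound 2 `O=C1C=C(Nc2ccc(Br)cc2)C(=O)c2c1nc1n2[C@H]2OC[C@@H](O)[C@H]2OC1` gives 2580 nM in this assay. On the numbers shown, compound 2 stands lowest of the two, with compound 1 as its nearest neighbour, but that gap lies within the scatter, so nothing separates the two compounds.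

Compound 3 `O=C1C=C(Nc2cccc(Cl)c2)C(=O)c2c1nc1n2[C@H]2OC[C@@H](O)[C@H]2OC1` is the untested member; it differs from compound 2 by 3-chlorophenyl in place of 4-bromophenyl on an amine nitrogen. Going by the values given here, no step between measured compounds covers this change, so the data give no direct measure of its size. Compounds 1 and 2 differ only in the group on the amine nitrogen and sit within the scatter of each other, which suggests that variation at this position has not produced large shifts so far. In this assay the step of a 1.2-fold higher number from compound 2 to compound 3 (0.07 log units; within the scatter) is expected to be small, within the scatter, with no direction claimed. Compound 3 is therefore estimated at 3000 nM, within a range from 1200 nM to 8000 nM.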

Compound 3, half-maximal inhibitory concentration: 4720 nM
The estimate for compound 3 lay 1.6-fold (0.20 log units) below the measured number; measured number inside the range.
By their numbers in this assay, from the lowest: compounds 2, 1 and 3 (each within the scatter of the next).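

The exchange of 4-bromophenyl for 3-chlorophenyl on an amine nitrogen now has a direct measure in this assay, with a 1.8-fold higher number from compound 2 to compound 3 (0.26 log units; within the scatter), and this single step alters both the halogen and where it sits on the phenyl ring, so it does not tell the two alterations apart. With compound 3 added, the three compounds form a series in which each stands within the scatter of the next, so no order among these aryl groups can be claimed, and this now holds for two halogen-bearing phenyl groups as well as for the group on the nitrogen of compound 1. Nothing at hand bears on what lies behind these numbers.

The compounds shown leave open whether any group on this nitrogen can move the number beyond the scatter, since all three carry a substituted phenyl ring. A plain phenyl, a benzyl group, a straight alkyl chain, or a phenyl ring bearing a carboxylic acid or an amine would test this, as would 3-bromophenyl or 4-chlorophenyl, which would separate the halogen from its place on the ring.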